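Nitro-to-chloro exchange on the benzimidazole-bearing quinolinone series

The source may hold more compounds than are shown below. What is called first, only, known or untested is meant among the compounds shown, and "the series" means these compounds.

Measured compounds:
compound 1 `Cc1ccc2[nH]c(=O)c(-c3nc4cc([N+](=O)[O-])ccc4[nH]3)cc2c1`, > 100000 nM
compound 2 `O=c1[nH]c2ccccc2cc1-c1nc2cc([N+](=O)[O-])ccc2[nH]1`, > 100000 nM
compound 3 `COc1ccc2[nH]c(=O)c(-c3nc4cc([N+](=O)[O-])ccc4[nH]3)cc2c1`, > 100000 nM

In a functional assay on HepG2 cells (Homo sapiens) for cytotoxicity, read by MTT assay, with a stated time of 48 h (on this read-out lower numbers stand for stronger inhibition and higher numbers for weaker inhibition), compound 1 gives > 100000 nM, which is a limit of the assay and not a number. In this assay compound 2 likewise gives only a limit, > 100000 nM. Compound 3 also sits at a limit, > 100000 nM. As a result the steps a step that the two limits leave unreadable from compound 1 to compound 2, a step that the two limits leave unreadable from compound 1 to compound 3 and a step that the two limits leave unreadable from compound 2 to compound 3 cannot be read, and compound 2 stands at the same limit as both others, as the limit of > 100000 nM in this assay, at which 3 of the 3 values shown sit, shows.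

Compound 4 `O=c1[nH]c2ccccc2cc1-c1nc2cc(Cl)ccc2[nH]1` is not yet measured. Its change from compound 2 is chloro in place of nitro on an aromatic carbon. No measured step involves the nitro group, so nothing among the shown steps bears directly on this change; the three readings at the limit leave the direction open.

Compound 4 is therefore expected to give 100000 nM, within 30000 nM to 300000 nM. The expected step is a number no higher from compound 2 to compound 4 (the limit leaves the size open), with a real chance that only a limit is again reported.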

Compound 4, half-maximal inhibitory concentration: 8450 nM
Compound 4: middle estimate off by 12-fold (1.07 log units), on the high side; the measured number lies below the stated range.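

In this assay, within the data shown here, the steps among compound 1, compound 2 and compound 3 cannot be read, whereas the move from nitro to chloro gives the first readable step: an at least 11-fold lower number from compound 2 to compound 4 (1.07 log units; beyond the scatter). The position is therefore sensitive to what it carries, and compound 4 at 8450 nM shows that this core can give a measured number, which none of the three nitro compounds does. The size of the step is only a floor, because compound 2 carries a limit and not a number: the limit of > 100000 nM in this assay, at which 3 of the 4 values shown sit.

On these data alone, it remains open whether chloro also gives a measured number on the cores of compound 1 and compound 3, which carry methyl and methoxy. As far as these compounds go, it is equally open whether the step belongs to chloro itself or to the loss of nitro, which bromo, an amine or a nitrile at the same carbon could help separate.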